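Indole-bearing aminopyran nitriles: from a naphthyl to a tolyl group

A few compounds are considered here, and "the series" means these few. Any claim that something is new, unique, unknown or untested is made for them only; others in the source may bear on it.

Measured so far:
compound 1, `COc1cc(Br)c(C2C(C#N)=C(N)OC(c3c[nH]c4ccccc34)=C2C#N)cc1OC`, 26.7%
compound 2, `N#CC1=C(N)OC(c2c[nH]c3ccccc23)=C(C#N)C1c1ccc2ccccc2c1`, "not active" (no number reported)

Compound 2 gives no number in a functional assay, tested at 400 ug/mL; on this read-out lower numbers stand for a weaker effect and higher numbers for a stronger effect at the one concentration tested; it is reported only as inactive, while compound 1 gives a modest read-out. The step to compound 3, `Cc1ccccc1C1C(C#N)=C(N)OC(c2c[nH]c3ccccc23)=C1C#N`, changes one group on the shared core: 2-methylphenyl in place of naphthalen-2-yl on a saturated ring carbon. Within the data shown here, no measured pair in this set shows this kind of change, so its size cannot be read from the data. With compound 2 inactive and compound 1 modestly active, a step upward of moderate size in this assay is expected for compound 3, but a result staying near inactivity is also possible. Compound 3 is expected to give about 15%, estimated between 0% and 35%.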

Compound 3, a percentage reported as activity, at one concentration (the size of the read-out at that concentration, not a potency): 25.7%
Compound 3: middle estimate off by 10.7 percentage points, on the low side, and the stated range covers the measured number.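

Compound 2 has no number in this assay, and the step from it to compound 3 cannot be read. As far as these compounds go, how far 2-methylphenyl in place of naphthalen-2-yl moves the read-out stays open. No other measurement shown bears on this result.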